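The compounds below may be only part of what the source reports. "The series", "measured", "known", "first", "only" and "open" are said of these compounds alone.

In a functional assay on the whole organism for inhibition, with Mus musculus as the target (a higher number here means that more compound is needed for the effect, a lower number that less compound is needed), compound 1 `CCNC(=O)Nc1cccc2c1CN(C)CC2c1ccccc1` gives 80 mg/kg, compound 2 `CCNCC(=O)Nc1cccc2c1CN(C)CC2c1ccccc1` gives 47 mg/kg and compound 3 `CC(C)NCC(=O)Nc1cccc2c1CN(C)CC2c1ccccc1` gives 14 mg/kg, the lowest number of the three. Compound 4 `CN1Cc2c(NC(=O)CN3CCCC3)cccc2C(c2ccccc2)C1` departs from compound 3 at one place: pyrrolidin-1-yl in place of isopropylamino on a saturated chain carbon bound to a carbonyl carbon. In words, this is pyrrolidin-1-yl in place of isopropylamino on a saturated chain carbon bound to a carbonyl carbon.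

The nearest measured change is a 3.4-fold lower number from compound 2 to compound 3 (0.53 log units; beyond the scatter), a modest step made on the same amino group. Two other steps bear on it less directly: a 1.7-fold lower number from compound 1 to compound 2 (0.23 log units; within the scatter), which stays within the scatter, and a 5.7-fold lower number from compound 1 to compound 3 (0.76 log units; beyond the scatter), also modest. Among the measured compounds shown here, no measured compound carries a ring on this amino group, so these steps offer only a guide to size. They give no reason to expect more than a modest step in this assay. Compound 3 already holds the lowest number at 14 mg/kg, so any expected drift leans towards a higher number. The expected change is a 1.4-fold higher number from compound 3 to compound 4 (0.15 log units; within the scatter). For compound 4 the estimate is 20 mg/kg, with an expected range of 7 mg/kg to 55 mg/kg.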

Compound 4, dose for half-maximal effect: 39 mg/kg
For compound 4 the middle estimate is 2.0-fold (0.29 log units) below the measured one; the range from low to high includes it.
By their numbers in this assay, from the lowest: compound 3; then compounds 4, 2 and 1 (each within the scatter of the next, the first and the last beyond it).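

In this assay, pyrrolidin-1-yl in place of isopropylamino gives a 2.8-fold higher number from compound 3 to compound 4 (0.44 log units; beyond the scatter), so the lower number of compound 3 does not carry over to this ring, which has no hydrogen-bond donor. Set against the smaller open amine, the ring gives a 1.2-fold lower number from compound 2 to compound 4 (0.08 log units; within the scatter), a step within the scatter, so compound 2 and compound 4 cannot be told apart here and the position accepts a ring without a clear change from ethylamino. Against ethylamino on the carbonyl carbon, (pyrrolidin-1-yl)methyl gives a 2.1-fold lower number from compound 1 to compound 4 (0.31 log units; beyond the scatter), a modest step beyond the scatter.

As far as these compounds go, whether piperidin-1-yl or tert-butylamino on this saturated chain carbon would lie closer to compound 3 or to compound 4 remains open. Nothing on hand explains why isopropylamino stands apart from pyrrolidin-1-yl in this series.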